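Notes on a chloro step from compound 1

The source may hold more compounds than are shown below. What is called first, only, known or untested is meant among the compounds shown, and "the series" means these compounds.

Measured so far:
- compound 1 `COc1ccc(-c2nc3sc(-c4ccccc4)cn3n2)cc1` gives 63%
- compound 2 `COc1cc(-c2nc3sc(-c4ccccc4)cn3n2)cc(OC)c1OC` gives 15%

Both values come from a functional assay on COLO 205 cells (Homo sapiens) for inhibition, read by sulforhodamine B assay, with a stated time of 48 h, tested at 10 uM (a higher number here means more inhibition of growth at the concentration tested, a lower number less inhibition of growth), and no other read-out is available. In this assay compound 1 at 63% stands highest of the two measured compounds. Compound 2 at 15% lies lower by a gap beyond the usual scatter.

The next compound is compound 3 `COc1ccc(-c2nc3sc(-c4ccc(Cl)cc4)cn3n2)cc1`, which keeps the core of compound 1 and turns phenyl to 4-chlorophenyl. The counted change is chloro in place of hydrogen on an aromatic carbon and it places chloro in place of hydrogen on an aromatic carbon, para to a large group.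

Going by the values given here, no measured pair shows a step of this kind, and the data offer no precedent for its size or direction. The expectation therefore starts from compound 1 at 63% and assumes no step beyond the scatter, in either direction. The expected change is a number 3 percentage points lower from compound 1 to compound 3 (within the scatter) and this remains an estimate with a wide margin. Compound 3 is estimated at 60% with an expected range from 35% to 85% in this assay when it is measured.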

Compound 3, percent growth inhibition at one concentration: 47.5%
The estimate for compound 3 lay 12.5 percentage points above the measured number, and the stated range covers the measured number.
By their numbers in this assay, from the lowest: compound 2; then compound 3; then compound 1.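

In this assay, going by these compounds alone, phenyl to 4-chlorophenyl gives the only readable step: a number 15.5 percentage points lower from compound 1 to compound 3 (beyond the scatter). This shows that the phenyl ring of compound 1 is sensitive to a change at the place para to a large group, since a single chloro in place of hydrogen there moves the number by more than the scatter, although compound 3 still gives 47.5%. The data give no measured property that could account for this step.

The compounds shown leave open whether the loss is specific to chloro or would also follow from other groups at this place, such as fluoro, an amine or a carboxylic acid, and a single step gives no trend across substituents. Going by these compounds, it also remains open whether the same chloro change would give a step of similar size and direction on compound 2, and whether the step seen at this single concentration would hold across a full concentration range.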